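The source may hold more compounds than are shown below. What is called first, only, known or untested is meant among the compounds shown, and "the series" means these compounds.

Working notes on the series. In an ADME assay on HEK293 cells (Homo sapiens) for cytotoxicity, with a stated time of 72 h (a lower number here means that less compound is needed, a higher number that more compound is needed for the effect), compound 3 `Cc1ccc(-c2nc3ccccc3s2)cc1NC(=O)c1cc([N+](=O)[O-])ccc1Cl` gives > 14000 nM, which is a limit and not a number. Compound 1 `O=C(Nc1cccc(-c2nc3ccccc3s2)c1)c1cc([N+](=O)[O-])ccc1Cl` gives > 27000 nM, also a limit. Compound 2 `COc1ccc(-c2nc3ccccc3s2)cc1NC(=O)c1cc([N+](=O)[O-])ccc1Cl` gives > 25000 nM, again a limit. Among the measured compounds shown here, no measured compound in this set therefore has a readable value in this assay.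

Compound 4 `O=C(Nc1cc(-c2nc3ccccc3s2)ccc1F)c1cc([N+](=O)[O-])ccc1Cl` takes fluoro in place of methyl on an aromatic carbon, relative to compound 3: fluoro in place of methyl on an aromatic carbon.

For the measured compounds named here, three measured steps bear on this change. Methyl in place of methoxy gives a step that the two limits leave unreadable from compound 2 to compound 3. Methyl in place of hydrogen gives a step that the two limits leave unreadable from compound 1 to compound 3. Methoxy in place of hydrogen gives a step that the two limits leave unreadable from compound 1 to compound 2. Going by the values given here, none of these steps has a size that can be carried over, and no measured compound carries fluoro. The data therefore give no ground for expecting a shift in either direction.

The expected step is a step that the limit leaves unreadable from compound 3 to compound 4, which means no change beyond the usual scatter. Compound 4 is more likely than not to be reported as a limit as well. For compound 4 the estimated value is 20000 nM, with an expected range of 9000 nM to 45000 nM.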

Compound 4, half-maximal effective concentration: > 25000 nM
Compound 4 ended at the assay's limit; the forecaster's own chance of this, stated with the estimate: 85%; middle value at least 1.2-fold (0.09 log units) from the limit.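

In this assay compound 4 gives > 25000 nM, a limit and not a number. Among the compounds shown here, compounds 1, 2 and 3 also stand at limits, so no step from any of them to compound 4 can be read. The compounds shown leave open whether hydrogen, methyl, methoxy or fluoro at this place differ at all in half-maximal effective concentration.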